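The compounds below may be only part of what the source reports. "The series", "measured", "known", "first", "only" and "open" are said of these compounds alone.

Measured so far:
Compound 1, `CCCC(=O)OCCc1c(-c2ccccc2Cl)c2cc(Cl)ccc2[nH]c1=O`, gives 52000 nM in an ADME assay on HepG2 2.2.15 cells (Homo sapiens) for cytotoxicity; on this read-out higher numbers stand for lower toxicity in this test and lower numbers for higher toxicity in this test.
Compound 2, `O=C(OCCc1c(-c2ccccc2Cl)c2cc(Cl)ccc2[nH]c1=O)c1ccc([N+](=O)[O-])cc1`, gives 1600000 nM in this assay.

Among the compounds with values here, compound 2 stands highest of these two numbers; the only other compound is compound 1, and the single measured step, a 31-fold higher number from compound 1 to compound 2 (1.49 log units; beyond the scatter), lies beyond the scatter. Compound 3, `COc1cccc(/C=C/C(=O)OCCc2c(-c3ccccc3Cl)c3cc(Cl)ccc3[nH]c2=O)c1`, has not yet been measured. It differs from compound 2 in one place: 2-(3-methoxyphenyl)ethenyl in place of 4-nitrophenyl on a carbonyl carbon. Within the data shown here, the only step that bears on this change is the one from compound 1 to compound 2, which also exchanged the group on the same carbonyl carbon and was large. The present exchange swaps one aromatic group for another, so a shift of that size is not expected; a modest move downward, a 2.7-fold lower number from compound 2 to compound 3 (0.43 log units; beyond the scatter), is estimated. Compound 3 is therefore expected near 600000 nM, within a range from 150000 nM to 2500000 nM.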

Compound 3, half-maximal cytotoxic concentration: > 1300000 nM
Compound 3 ended at the assay's limit; the forecaster's own chance of this, stated with the estimate: 25%; at least 2.1-fold (0.33 log units) between middle value and limit.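

In this assay compound 3 gives > 1300000 nM, which is a limit of the assay and not a number: the limit of > 1300000 nM in this assay, at which 1 of the 3 values shown sits. Going by these compounds, the step between compound 2 and compound 3 therefore cannot be read, and the order of these two stays unknown. What can be read is an at least 25-fold higher number from compound 1 to compound 3 (1.39 log units; beyond the scatter), so a second aromatic-ring group on this carbonyl carbon, 2-(3-methoxyphenyl)ethenyl as well as the 4-nitrophenyl of compound 2, goes with a far higher number than propyl does.

The compounds shown leave open whether the aromatic ring itself matters or whether any group with more heavy atoms than propyl would do, which a longer plain chain such as octyl or a saturated ring such as cyclohexyl on the same carbonyl carbon could separate. On these data alone, how an amine or a carboxylic acid in this group would read also stays open.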